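Replacing an aromatic triazole with a substituted non-aromatic ring

The compounds below may be only part of what the source reports. "The series", "measured", "known", "first", "only" and "open" are said of these compounds alone.

Measured so far in a physicochemical assay for metabolic stability, read by HPLC and mass spectrometry, in phosphate buffer, at 37 degrees C, at pH 7.4; a higher number here means that the compound lasts longer, a lower number that the compound disappears faster:
Compound 1, `CC(C)(O/N=C(\C(=O)N[C@@H]1C(=O)N(S(=O)(=O)O)[C@@H]1CN1CCCC1=O)c1csc(N)n1)C(=O)O`: compound 1 sits at a limit of the assay, > 1000 h.
Compound 2, `CC(C)(O/N=C(\C(=O)N[C@@H]1C(=O)N(S(=O)(=O)O)[C@@H]1Cn1cncn1)c1csc(N)n1)C(=O)O`: compound 2 gives 233 h.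

Among the measured compounds shown here, compound 2 holds the only actual number in this assay; the other value shown is only a limit (the limit of > 1000 h in this assay, at which 1 of the 2 values shown sits). For the measured compounds named here, the single measured step is an at least 4.2-fold lower number from compound 1 to compound 2 (0.63 log units; beyond the scatter), so the aromatic ring coincides with the lower number.

Compound 3, `CC(C)(O/N=C(\C(=O)N[C@@H]1C(=O)N(S(=O)(=O)O)[C@@H]1CN1C[C@@H](CNC(=N)N)OC1=O)c1csc(N)n1)C(=O)O`, differs from compound 2 as follows: a group of 11 heavy atoms (5 carbon, 4 nitrogen, 2 oxygen; one five-membered non-aromatic ring with 2 hetero atoms) in place of a group of 5 heavy atoms (2 carbon, 3 nitrogen; one five-membered aromatic ring with 3 hetero atoms), on a saturated chain carbon bound to a saturated ring carbon. This change bears on the same place as the measured step, and it moves away from the aromatic ring in compound 2 toward a five-membered non-aromatic ring, as in compound 1. Going by the values given here, a move back upward in this assay is therefore expected, at least modest in size, though with only one step to rest on the range is wide. Compound 3 is expected to give about 600 h, with a range from 200 h to 1500 h. That would be an expected step of a 2.6-fold higher number from compound 2 to compound 3 (0.41 log units; beyond the scatter).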

Compound 3, half-life: > 37 h
Compound 3: a limit, no number; the forecaster's own chance of this, stated with the estimate: 30%; the middle value lies beyond the limit too.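

In this assay compound 3 gives > 37 h, which is a limit and not a number, so its steps from compound 2 and from compound 1 cannot be read. The compounds shown leave open whether compound 3 lasts longer or shorter than either compound 2 or compound 1.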